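The source may hold more compounds than are shown below. What is called first, only, known or untested is meant among the compounds shown, and "the series" means these compounds.

Compound 2 `O=C(Nc1cccc(Br)c1)N[C@H]1CC[C@H](Oc2ccc(F)cc2)CC1` carries a shared core with a substituted phenyl group on an amide-type nitrogen. Going by the values given here, in a functional assay on CRL2813 cells (Homo sapiens) for cytotoxicity, read by sulforhodamine B assay, with a stated time of 5 days (a lower number here means a stronger inhibitor, a higher number a weaker inhibitor), compound 2 gives 6200 nM, the only outright number among the values shown. Compound 1 `CSc1ccc(NC(=O)N[C@H]2CC[C@H](Oc3ccc(F)cc3)CC2)cc1` in this assay reaches only a limit, > 20000 nM, and the limit of > 20000 nM in this assay, at which 1 of the 2 values shown sits, is where that limit sits. Among the compounds with values here, the single measured step, an at least 3.2-fold lower number from compound 1 to compound 2 (0.50 log units; beyond the scatter), shows that swapping the group on that amide-type nitrogen can move the number well beyond the scatter. Compound 3 `Cc1ccccc1NC(=O)N[C@H]1CC[C@H](Oc2ccc(F)cc2)CC1` is not yet measured; it differs from compound 2 by 2-methylphenyl in place of 3-bromophenyl on an amide-type nitrogen. Within the data shown here, the step from compound 1 to compound 2 is the only guide, and it concerns the same place in the molecule, so a step of comparable size in either direction is plausible here. A modest weakening is expected, with compound 3 estimated at 12000 nM (range 4000 nM to 30000 nM), which corresponds to an expected step of a 1.9-fold higher number from compound 2 to compound 3 (0.29 log units; within the scatter).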

Compound 3, half-maximal inhibitory concentration: > 20000 nM
Compound 3 was reported as a limit; the forecaster's own chance of this, stated with the estimate: 35%; middle value at least 1.6-fold (0.22 log units) away from the limit.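

Replacing 3-bromophenyl with 2-methylphenyl on the amide-type nitrogen gives an at least 3.2-fold higher number from compound 2 to compound 3 (0.50 log units; beyond the scatter), so a second replacement for 3-bromophenyl at this position also ends with a clearly higher number in this assay. Going by these compounds alone, compound 3 is reported only as a limit, the same limit reached by compound 1: the limit of > 20000 nM in this assay, at which 2 of the 3 values shown sit. The step between these two compounds cannot be read, so 2-methylphenyl and 4-(methylsulfanyl)phenyl cannot be ranked against each other, and 3-bromophenyl remains the only one of the three groups with an outright number.

The compounds shown leave open whether the outcome follows the bromine atom or its place on the ring, which a 3-methylphenyl or 2-bromophenyl group could help separate. Also open, on these data alone, is whether a phenyl ring carrying an amine or a carboxylic acid would give an outright number at all.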